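Dropping a Chloro Group: Permeability Expectation for Compound 3

The source may report more compounds than this note shows. Statements on the series, on what has been measured and on what is new or still open speak of the compounds shown alone.

Measured compounds:
compound 1 `CC(C)c1csc(-c2cccc(CN(C)c3ccc4[nH]nc(C(=O)O)c4c3)c2O)n1`: < 0.05 10^-6 cm/s
compound 2 `CN(C)c1noc(-c2cccc(CNc3ccc4[nH]nc(C(=O)O)c4c3)c2Cl)n1`: 0.7 10^-6 cm/s

Within the data shown here, in an ADME assay on MDCK cells (Canis lupus familiaris) for permeability, in the apical to basolateral direction (a higher number here means that the compound crosses the layer faster, a lower number that the compound crosses the layer more slowly), compound 2 gives 0.7 10^-6 cm/s, the only plain number measured here. The value for compound 1 is a limit of the assay rather than a number, namely (the limit of < 0.05 10^-6 cm/s in this assay, at which 1 of the 2 values shown sits). Compound 3 `CN(C)c1noc(-c2cccc(CNc3ccc4[nH]nc(C(=O)O)c4c3)c2)n1` differs from compound 2 by hydrogen in place of chloro on an aromatic carbon. Among the measured compounds shown here, no measured pair shows what this single change does, so the expectation rests on compound 2 alone. The step of a 1.4-fold lower number from compound 2 to compound 3 (0.15 log units; within the scatter) is expected to be small and slightly downward, close to the scatter. Compound 3 is thus estimated at 0.5 10^-6 cm/s, within a range from 0.15 10^-6 cm/s to 1.5 10^-6 cm/s.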

Compound 3, apparent permeability in the MDCK assay: 0.5 10^-6 cm/s
Estimate against measurement, compound 3: no gap at the digits printed; the range from low to high includes it.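

At this place, ortho to a 3-(dimethylamino)-1,2,4-oxadiazol-5-yl group, hydrogen in place of chloro stays within the scatter in the MDCK assay, with a 1.4-fold lower number from compound 2 to compound 3 (0.15 log units; within the scatter). The picture differs in a physicochemical assay for solubility, measured as kinetic solubility, at pH 2 (on this read-out higher numbers stand for higher solubility and lower numbers for lower solubility), where compound 2 gives 7000 nM and compound 3 gives 308000 nM. That is a 44-fold higher number from compound 2 to compound 3 (1.64 log units; beyond the scatter), so this single swap separates the two read-outs clearly.

On these data alone, how a methyl or methoxy group on this same carbon would fare in either read-out stays open. The compounds shown also give no reason why the two read-outs part ways.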